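The source may hold more compounds than are shown below. What is called first, only, known or untested is meant among the compounds shown, and "the series" means these compounds.

Measured compounds in an assay on CHO cells for activation of soluble guanylate cyclase alpha1/beta1 complex (Homo sapiens), read by cGMP accumulation; a higher number here means that more compound is needed for the effect, a lower number that less compound is needed:
- compound 1, `CC1(C)C(=O)Nc2nc(-n3nc(Cc4ccccc4F)c4cc(Cl)ccc43)nc(N)c21`, gives 18000 nM
- compound 2, `CC1(C)C(=O)Nc2nc(-n3nc(Cc4c(F)ccc(F)c4F)c4cc(Cl)ccc43)nc(N)c21`, gives 7300 nM

Going by the values given here, compound 2 stands at the lowest of the two numbers so far; the nearest is compound 1, and the step of a 2.5-fold lower number from compound 1 to compound 2 (0.39 log units; beyond the scatter) separates them, a modest change from adding two fluorine atoms to the ring on the saturated chain carbon bound to an aromatic carbon.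

Compound 3, `CC1(C)C(=O)Nc2nc(-n3nc(CCC(F)(F)F)c4cc(Cl)ccc43)nc(N)c21`, is not yet measured. Relative to compound 2 the change is 2,2,2-trifluoroethyl in place of 2,3,6-trifluorophenyl on a saturated chain carbon bound to an aromatic carbon. Among the compounds with values here, the only measured step, a 2.5-fold lower number from compound 1 to compound 2 (0.39 log units; beyond the scatter), alters the substitution of the same ring but keeps the ring itself, so it bears on this step only loosely; no measured pair here removes the ring. Within the data shown here, the data therefore give no direct guide to the size or direction of the step in this assay; given that the one known change in this region was modest, a step of moderate size is expected, somewhat more likely towards a higher number, with wide uncertainty. The estimate for compound 3 in this assay is 15000 nM, with a range of 4000 nM to 60000 nM, which means an expected step of a 2.1-fold higher number from compound 2 to compound 3 (0.31 log units; beyond the scatter).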

Compound 3, half-maximal effective concentration: 87000 nM
Compound 3: middle estimate off by 5.8-fold (0.76 log units), on the low side, and the stated range ends below it.
By their numbers in this assay, from the lowest: compound 2; then compound 1; then compound 3.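

In this assay, the position on a saturated chain carbon bound to an aromatic carbon proves sensitive to losing the ring: 2,2,2-trifluoroethyl in place of 2,3,6-trifluorophenyl gives a 12-fold higher number from compound 2 to compound 3 (1.08 log units; beyond the scatter), the largest step among the three compounds. The same kind of exchange starting from 2-fluorophenyl gives a 4.8-fold higher number from compound 1 to compound 3 (0.68 log units; beyond the scatter), so the number rises from either ring-bearing compound, and both lie below compound 3 whichever fluorine pattern the ring carries. No measurement accompanies these numbers that could account for the rise on removing the ring.

From the compounds shown here alone, it remains open whether a cyclohexyl group, an unsubstituted phenyl or a pyridine ring in this place would fall with compound 1 and compound 2 or with compound 3, which would show whether any ring serves or only an aromatic one. Going by these compounds, it is also open whether a longer fluorinated chain or a chain ending in an amine would recover any of the loss seen with compound 3, and all of this rests on one core and one assay.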